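The source may report more compounds than this note shows. Statements on the series, on what has been measured and on what is new or still open speak of the compounds shown alone.

Compound 1 `CCNCCn1c(N2CCN(C)CC2)nc2ccccc21`, compound 2 `COCCCn1c(N2CCN(C)CC2)nc2ccccc21` and compound 3 `COCCn1c(N2CCN(C)CC2)nc2ccccc21` have been measured. In a functional assay on ileum for inhibition of histamine H1 receptor (Cavia porcellus) (on this read-out higher numbers stand for weaker inhibition and lower numbers for stronger inhibition), compound 1 gives 290 nM, compound 2 gives 860 nM and compound 3 gives 13 nM.

Compound 3 stands lowest of the three, shown by a 22-fold lower number from compound 1 to compound 3 (1.35 log units; beyond the scatter) and a 66-fold lower number from compound 2 to compound 3 (1.82 log units; beyond the scatter). Compound 4 `CN1CCN(c2nc3ccccc3n2CCO)CC1` differs from compound 3 by hydrogen in place of methyl on an oxygen on a saturated carbon. For the measured compounds named here, no measured step removes a methyl from that oxygen, so nothing covers this change directly; the two steps that alter the same part of the chain were both large, and this counsels caution rather than confidence. A modest step is expected in this assay, most likely toward a higher number. Compound 4 is therefore expected to give about 40 nM, between 8 nM and 200 nM. That expectation corresponds to a 3.1-fold higher number from compound 3 to compound 4 (0.49 log units; beyond the scatter).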

Compound 4, half-maximal inhibitory concentration: 410 nM
Compound 4: the middle estimate sits 10-fold (1.01 log units) below what was measured; measured number above the stated range.
By their numbers in this assay, from the lowest: compound 3; then compounds 1 and 4 (each within the scatter of the next); then compound 2.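

In this assay, the methyl on the oxygen proves to matter on its own: the change from 2-methoxyethyl to 2-hydroxyethyl gives a 32-fold higher number from compound 3 to compound 4 (1.50 log units; beyond the scatter) as a large step. The other chains stand apart from compound 3 as well, for the hydroxy compound shows a 2.1-fold lower number from compound 2 to compound 4 (0.32 log units; beyond the scatter) and also a 1.4-fold higher number from compound 1 to compound 4 (0.15 log units; within the scatter) on this read-out. No evidence at hand accounts for this step. Still open, going by these compounds, is whether an ethoxy group on the same chain would keep the low number of compound 3, and whether a 3-hydroxypropyl chain would follow the 2-hydroxyethyl one.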